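The source may report more compounds than this note shows. Statements on the series, on what has been measured and on what is new or still open speak of the compounds shown alone.

Measured so far: compound 1 `CCCCCCCC/C=C\CCCCCCCC(OC)OC`, compound 2 `CCCCCCCC/C=C\CCCCCCC(=O)c1ncc(-c2ccncc2)o1`, compound 3 `CCCCCCCC/C=C\CCCCCCC(=O)c1cccnn1`.

In an assay on isolated protein for inhibition of Fatty-acid amide hydrolase 1 (Homo sapiens) (a higher number here means a weaker inhibitor, a lower number a stronger inhibitor), compound 1 reaches only the limit of > 300000 nM. Compound 2 gives 56 nM and compound 3 gives 130 nM, so compound 3 carries the highest of the two numbers, with compound 2 nearest. Among the compounds with values here, the single measured step, an at least 2300-fold lower number from compound 1 to compound 3 (3.36 log units; beyond the scatter), concerns a different part of the molecule and bears only loosely on the path to compound 4 `CCCCCCCC/C=C\CCCCCCC(=O)c1ncco1`, whose change is 1,3-oxazol-2-yl in place of pyridazin-3-yl on a carbonyl carbon. Compounds 2 and 3 show that the ring on the carbonyl matters, but their difference is not the one made here. Compound 4 is therefore expected to move by a 7.7-fold higher number from compound 3 to compound 4 (0.89 log units; beyond the scatter). Compound 4 is estimated at 1000 nM, within 200 nM to 5000 nM.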

Compound 4, inhibition constant: 17 nM
Compound 4: the middle estimate sits 59-fold (1.77 log units) above what was measured; the measured number lies below the stated range.
By their numbers in this assay, from the lowest: compound 4; then compound 2; then compound 3. At a limit, above all of these: compound 1.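

In this assay the ring on the carbonyl carbon counts on its own, with a 7.6-fold lower number from compound 3 to compound 4 (0.88 log units; beyond the scatter) when 1,3-oxazol-2-yl takes the place of pyridazin-3-yl. The pyridin-4-yl of compound 2 is not needed for strong inhibition, as hydrogen on that aromatic carbon gives a 3.3-fold lower number from compound 2 to compound 4 (0.52 log units; beyond the scatter) and the number falls further. The step to the (1,3-oxazol-2-yl)carbonyl group, an at least 17000-fold lower number from compound 1 to compound 4 (4.24 log units; beyond the scatter), starts from a limit and not from a number: the limit of > 300000 nM in this assay, at which 1 of the 4 values shown sits.

Still open, on these data alone, is whether a carboxylic acid or a methyl ester on that aromatic carbon would lower the number further. Also open, as far as these compounds go, is how far this ring carries over to a saturated or shorter chain.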